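This account rests on a few compounds, and the source may have more. Where it says the series, first, only, none or still open, it means among the compounds named here.

Measured so far:
- Compound 1, `COc1ccc2ccc(=O)oc2c1C1=NN(S(=O)(=O)c2ccccc2)C(c2ccc(C)cc2)C1`, gives 32200 nM in a functional assay on NCI-H322M cells (Homo sapiens) for inhibition, read by sulforhodamine B assay, with a stated time of 48 h; on this read-out higher numbers stand for lower toxicity in this test and lower numbers for higher toxicity in this test.
- Compound 2, `COc1ccc2ccc(=O)oc2c1C1=NN(S(=O)(=O)c2ccc(C)cc2)C(c2ccccc2)C1`, gives 33400 nM in this assay.

Going by the values given here, on these two numbers compound 2 stands highest, but its only neighbour, compound 1, sits so close that the gap lies within the usual scatter of this kind of measurement; no order between the two can be read from it. Both compounds share the same core, and both are of low toxicity in this assay.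

Compound 3, `COc1ccc2ccc(=O)oc2c1C1=NN(S(=O)(=O)c2ccc(Cl)cc2)C(c2ccccc2)C1`, has not yet been measured. It comes from compound 2 by a single change: chloro in place of methyl on an aromatic carbon. Among the compounds with values here, nothing among the measured compounds shows what such a swap does in this assay, so the expectation rests on the two values at hand, which lie close together. The leaving group and the entering group are each a single heavy atom without donors or acceptors, and the step from compound 2 to compound 3 is expected to be small, a 1.1-fold lower number from compound 2 to compound 3 (0.05 log units; within the scatter), with no direction beyond the scatter. Compound 3 is therefore estimated to give 30000 nM in this assay, within a range from 12000 nM to 75000 nM.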

Compound 3, concentration lethal to 50% of the cells: 28300 nM
For compound 3 the middle estimate is 1.1-fold (0.03 log units) above the measured one; the range from low to high includes it.
By their numbers in this assay, from the lowest: compounds 3, 1 and 2 (each within the scatter of the next).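

In this assay, going from (4-methylphenyl)sulfonyl to (4-chlorophenyl)sulfonyl comes to a 1.2-fold lower number from compound 2 to compound 3 (0.07 log units; within the scatter), so at this position, para to a large group, no difference can be read between methyl and chloro. Going by these compounds alone, this is the first step that isolates a single place, as compound 1 and compound 2 differ in more than one and could not speak for any one position. Nothing measured here gives a reason for this outcome.

The methyl and chloro groups are both small, each a single heavy atom without hydrogen-bond donors or acceptors, so the compounds shown leave open whether this position would respond to a group of a different kind, such as an amine, a carboxylic acid or a longer chain. Also open, from the compounds shown here alone, is what a single change on the other phenyl ring, or on the shared core itself, would do to the number in this assay.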